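Replacing 4-fluorophenyl with 2,4-dichlorophenyl in compound 3

This account rests on a few compounds, and the source may have more. Where it says the series, first, only, none or still open, it means among the compounds named here.

In a functional assay on THP-1 cells (Homo sapiens) for cytotoxicity, read by MTT assay, with a stated time of 24 h (on this read-out lower numbers stand for stronger inhibition and higher numbers for weaker inhibition), compound 1 `COc1cc(/C=C2\CN(C)C/C(=C\c3ccccc3F)C2=O)cc(OC)c1` gives 1170 nM. Compound 2 `COc1cc(/C=C2\CN(C)C/C(=C\c3cc(OC)c(OC)c(OC)c3)C2=O)cc(OC)c1` gives 720 nM. Compound 3 `CN1C/C(=C\c2ccc(F)cc2)C(=O)/C(=C/c2cccc([N+](=O)[O-])c2)C1` gives 7160 nM, the highest of the three numbers and the weakest result, with both other compounds lying lower beyond the scatter. Compound 4 `CN1C/C(=C\c2cccc([N+](=O)[O-])c2)C(=O)/C(=C/c2ccc(Cl)cc2Cl)C1` has not yet been measured. It carries 2,4-dichlorophenyl in place of 4-fluorophenyl on a double-bonded chain carbon bound to a double-bonded ring carbon. For the measured compounds named here, no measured pair differs in one place only, so the data offer no direct precedent. In this assay, a moderate step to a lower number, slightly beyond the scatter, is expected, since compound 3 at 7160 nM stands at the top of the measured numbers. The estimated change is a 2.4-fold lower number from compound 3 to compound 4 (0.38 log units; beyond the scatter). For compound 4 the expected value is 3000 nM, within an estimated range of 900 nM to 9000 nM.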

Compound 4, half-maximal inhibitory concentration: 3560 nM
The estimate for compound 4 lay 1.2-fold (0.07 log units) below the measured number, within the range that was stated.
By their numbers in this assay, from the lowest: compounds 2 and 1 (each within the scatter of the next); then compounds 4 and 3 (each within the scatter of the next).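

In this assay, for the compounds shown here, exchanging the 4-fluorophenyl group for 2,4-dichlorophenyl gives a 2.0-fold lower number from compound 3 to compound 4 (0.30 log units; within the scatter), the first comparison here that differs in one place only. At this position, therefore, the two groups cannot be told apart in this read-out, despite the two chlorine atoms entering and the fluorine leaving. Nothing measured here bears on this result. The compounds shown leave open how a phenyl group carrying an amine or a carboxylic acid would read at this position. They also leave open whether a single chlorine would give a similar number.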